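The compounds below may be only part of what the source reports. "The series", "measured", "known", "first", "only" and "open" are said of these compounds alone.

Measured compounds:
- compound 1, `O=C(CI)NCCCCCCCNc1ncnc2c1ncn2[C@@H]1O[C@H](COP(=O)(O)OP(=O)(O)OP(=O)(O)O)[C@@H](O)[C@H]1O`: 20%
- compound 2, `CN(CCCCN(C)c1ncnc2c1ncn2[C@@H]1O[C@H](COP(=O)(O)OP(=O)(O)OP(=O)(O)O)[C@@H](O)[C@H]1O)C(=O)CCCCCNC(=O)CI`: 0%

Compound 1 is `O=C(CI)NCCCCCCCNc1ncnc2c1ncn2[C@@H]1O[C@H](COP(=O)(O)OP(=O)(O)OP(=O)(O)O)[C@@H](O)[C@H]1O`. In an assay on isolated protein for inhibition of hexokinase-1 (Rattus norvegicus), with a stated time of 6 h, tested at 10 mM (a higher number here means more inhibition at the concentration tested (going by the name of the read-out), a lower number less inhibition), compound 1 gives 20%. Compound 2 is `CN(CCCCN(C)c1ncnc2c1ncn2[C@@H]1O[C@H](COP(=O)(O)OP(=O)(O)OP(=O)(O)O)[C@@H](O)[C@H]1O)C(=O)CCCCCNC(=O)CI`; in this assay compound 2 gives 0%. Compound 1 stands highest of the two numbers; its nearest neighbour is compound 2, whose reading is lower by a gap beyond the usual scatter. Among the compounds with values here, compound 2 differs from compound 1 in more than one place, so no single step between them is counted; their two values are simply what they show.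

Compound 3 is `O=C(CI)NCCC(=O)NCCCCCCNc1ncnc2c1ncn2[C@@H]1O[C@H](COP(=O)(O)OP(=O)(O)OP(=O)(O)O)[C@@H](O)[C@H]1O` and has not been measured in this assay. Relative to compound 1 the change is a group of 10 heavy atoms (5 carbon, 2 nitrogen, 2 oxygen, 1 iodine; no ring) in place of a group of 6 heavy atoms (3 carbon, 1 nitrogen, 1 oxygen, 1 iodine; no ring), on a saturated chain carbon, six bonds along the chain from a nitrogen on an aromatic ring. The shared core and the chain to the ring nitrogen are kept; the chain beyond that point is made longer by the entering group.

Within the data shown here, no step between measured compounds with a single change is available, so the size of the step is open. The expected step from compound 1 to compound 3 is a number 7 percentage points lower from compound 1 to compound 3 (within the scatter), small and downward, most likely within the scatter. Compound 3 is estimated at 13%, with a range from 0% to 30%.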

Compound 3, a percentage reported as inhibition, at one concentration (the size of the read-out at that concentration, not a potency): 0%
For compound 3 the middle estimate is 13 percentage points above the measured one; the measured number falls inside the stated range.
By their numbers in this assay, from the lowest: compounds 2 and 3 (each within the scatter of the next); then compound 1.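

In this assay, the change on a saturated chain carbon, six bonds along the chain from a nitrogen on an aromatic ring, gives a number 20 percentage points lower from compound 1 to compound 3 (beyond the scatter), the first single-place step available in this series. The entering group still holds 1 iodine, yet compound 3 reads 0%, so the presence of iodine in the group does not by itself keep the reading of compound 1 at this position. Nothing measured on hand accounts for the step.

The compounds shown do not separate the added chain length from the added carbonyl and amide hydrogen of the entering group, so a plain longer carbon chain with the same iodomethyl carbonyl amino end, or a shorter chain, would be needed to tell these apart. As far as these compounds go, it also remains open whether a chloromethyl or bromomethyl carbonyl in place of the iodomethyl carbonyl would keep the reading of compound 1, and how the series behaves at other concentrations, since each reading here comes from a single one.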